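Replacing piperidin-4-yl on the shared core

The compounds below may be only part of what the source reports. "The series", "measured", "known", "first", "only" and "open" are said of these compounds alone.

Measured in a functional assay on HCT-116 cells (Homo sapiens) for antiproliferative activity, read by MTT assay, with a stated time of 24 h (a higher number here means a weaker inhibitor, a lower number a stronger inhibitor), so far:
compound 1 `COc1ccc(-c2noc(C3CCCN3)n2)cc1OC1CCCC1` gives 185000 nM
compound 2 `COc1ccc(-c2noc(C3CCNCC3)n2)cc1OC1CCCC1` gives 1540 nM

Compound 2 holds the lower of the two numbers. Compound 3 `COc1ccc(-c2noc(-c3cccnc3)n2)cc1OC1CCCC1` is not yet measured and differs from compound 2 by pyridin-3-yl in place of piperidin-4-yl on an aromatic carbon, with pyridin-3-yl in place of piperidin-4-yl on an aromatic carbon. Among the compounds with values here, the one measured step, a 120-fold lower number from compound 1 to compound 2 (2.08 log units; beyond the scatter), is large and falls at the same place, so a step beyond the scatter is plausible here. Its direction is not shown by that step, but a higher number is tentatively expected. The expected step is a 5.2-fold higher number from compound 2 to compound 3 (0.72 log units; beyond the scatter) in this assay overall. For compound 3 the estimate is 8000 nM, within an expected range of 1200 nM to 55000 nM overall.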

Compound 3, half-maximal inhibitory concentration: > 1000000 nM
Compound 3 gave a limit, no number; the forecaster's own chance of this, stated with the estimate: 5%; at least 120-fold (2.09 log units) between middle value and limit.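

In this assay compound 3 stands as a limit of the assay and not a number: the limit of > 1000000 nM in this assay, at which 1 of the 3 values shown sits. Pyridin-3-yl on this aromatic carbon gives an at least 640-fold higher number from compound 2 to compound 3 (2.81 log units; beyond the scatter) and an at least 5.4-fold higher number from compound 1 to compound 3 (0.73 log units; beyond the scatter), so this aromatic ring reads weaker than both non-aromatic rings shown. The earlier pair showed only a spread between two non-aromatic rings; here the change to an aromatic ring and the loss of the hydrogen-bond donor come together and cannot be separated.

On these data alone, whether the ring nitrogen is needed at all stays open, and a cyclohexyl group on the same carbon would address that. An open-chain amine there would show whether any ring is required.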